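Moving a Hexyl Chain Around a Shared Core

A few compounds are considered here, and "the series" means these few. Any claim that something is new, unique, unknown or untested is made for them only; others in the source may bear on it.

Compound 1 `O=C(O)CCCC(=O)n1ccc2ccccc21`: > 30000 nM
Compound 2 `CCCCCCc1cn(C(=O)CCCC(=O)O)c2ccccc12`: 20700 nM
Compound 3 `CCCCCCc1ccc2c(ccn2C(=O)CCCC(=O)O)c1`: 17700 nM

In a functional assay on isolated protein for antagonist activity at Oxoeicosanoid receptor 1 (Homo sapiens), read by fluorescence and calcium flux, with stated times of 2 min and 1 min (a lower number here means a stronger inhibitor, a higher number a weaker inhibitor), compound 1 gives only a limit, > 30000 nM, so its strength is not known as a number (the limit of > 30000 nM in this assay, at which 1 of the 3 values shown sits). Compound 4 `CCCCCCc1ccc2ccn(C(=O)CCCC(=O)O)c2c1` differs from compound 1 in one place: hexyl in place of hydrogen on an aromatic carbon. Among the measured compounds shown here, two measured steps bear on this change. The first, an at least 1.4-fold lower number from compound 1 to compound 2 (0.16 log units; that floor lies within the scatter), and the second, an at least 1.6-fold lower number from compound 1 to compound 3 (0.22 log units; that floor lies within the scatter), each put hexyl in place of hydrogen on an aromatic carbon at a different spot on the shared core, and each reaches only a floor that lies within the scatter. In this assay compound 2 gives 20700 nM, and compound 3 gives 17700 nM, two numbers within the scatter of each other. For compound 4 a similar outcome is expected, a weak inhibitor with a step of an at least 1.6-fold lower number from compound 1 to compound 4 (0.22 log units; that floor lies within the scatter) that may itself stay within the scatter. Compound 4 is therefore estimated at 18000 nM, most likely between 8000 nM and 40000 nM.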

Compound 4, half-maximal inhibitory concentration: 18000 nM
Compound 4: the middle estimate sits on the measured number at the digits printed; the range from low to high includes it.
By their numbers in this assay, from the lowest: compounds 3, 4 and 2 (each within the scatter of the next). At a limit, above all of these: compound 1.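

In this assay, hexyl in place of hydrogen at this third spot on the shared core gives a step that reaches only a floor (an at least 1.6-fold lower number from compound 1 to compound 4 (0.22 log units; that floor lies within the scatter)) and leaves a weak inhibitor. Compound 4, with the hexyl on an aromatic carbon of a six-membered aromatic ring of carbon only, stands within the scatter of compounds 2 and 3, so none of the three spots shown sets itself apart from the others. How much hexyl adds at this position stays unknown because the comparison rests on compound 1, whose value is only a limit: the limit of > 30000 nM in this assay, at which 1 of the 4 values shown sits.

On these data alone, whether an amine, a carboxylic acid or a longer chain at this same position would move the number beyond the scatter remains open. So does the true size of the change from compound 1, until that compound has a number rather than a limit.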